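From bromo to cyano on compound 3

The source may report more compounds than this note shows. Statements on the series, on what has been measured and on what is new or still open speak of the compounds shown alone.

Measured in a functional assay on HepG2 cells (Homo sapiens) for cytotoxicity, read by MTT assay, with a stated time of 24 h; a higher number here means a weaker inhibitor, a lower number a stronger inhibitor:
- Compound 1 `COc1ccc(/C=C2\CN(C)C/C(=C\c3ccccc3F)C2=O)cc1OC` gives 8760 nM
- Compound 2 `CN1C/C(=C\c2ccc(C(F)(F)F)cc2)C(=O)/C(=C/c2ccccc2F)C1` gives 4140 nM
- Compound 3 `COc1cc(/C=C2\CN(C)C/C(=C\c3ccc(Br)cc3)C2=O)cc(OC)c1` gives 4840 nM

Within the data shown here, of these three numbers, the one for compound 3 is the second highest, yet it lies within the usual scatter of both compound 2 and compound 1.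

The account now turns to compound 4 `COc1cc(/C=C2\CN(C)C/C(=C\c3ccc(C#N)cc3)C2=O)cc(OC)c1` which has not yet been measured. It differs from compound 3 in one place, with cyano in place of bromo on an aromatic carbon, para to a large group (cyano in place of bromo on an aromatic carbon).

Among the measured compounds shown here, no two measured compounds differ in one place only, so the data give no direct guide to this change. The expectation therefore rests on compound 3 at 4840 nM and no step beyond the scatter is expected in this assay in either direction. The estimate amounts to a 1.0-fold higher number from compound 3 to compound 4 (0.01 log units; within the scatter) and so stays within the scatter. In this assay compound 4 is expected at 5000 nM with an estimated range from 2500 nM to 10000 nM as its likely span.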

Compound 4, half-maximal inhibitory concentration: 880 nM
For compound 4 the middle estimate is 5.7-fold (0.75 log units) above the measured one; measured number outside the range, below it.
By their numbers in this assay, from the lowest: compound 4; then compounds 2, 3 and 1 (each within the scatter of the next, the first and the last beyond it).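

The pair formed by compound 3 and compound 4 is the first among those shown to differ in one place only, so the aromatic carbon para to a large group can now be read directly: in this assay, cyano in place of bromo gives a 5.5-fold lower number from compound 3 to compound 4 (0.74 log units; beyond the scatter), a step beyond the usual scatter. This position is not indifferent to the group it carries. With the rest of compound 3 held fixed, this one exchange, in which the count of hydrogen-bond acceptors goes from 0 to 1, is enough to give a stronger inhibitor in this cell assay. No measurement shown bears on what lies behind the step, which stands as an observation for this single pair.

Whether the step is particular to cyano remains open, since the compounds shown do not tell how an amine or a carboxylic acid at the same position would compare. On these data alone, it is equally open whether the same exchange would give a step of like size on the other aromatic ring patterns seen in compound 1 and compound 2.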